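Adding a dihydroxyphenyl group to compound 1

The source may hold more compounds than are shown below. What is called first, only, known or untested is meant among the compounds shown, and "the series" means these compounds.

Values measured in an ADME assay on MDCK cells (Canis lupus familiaris) for cytotoxicity; a lower number here means that less compound is tolerated, a higher number that more compound is tolerated
compound 1 `O=[N+]([O-])C1=CNc2nc(-c3ccco3)nn2C1` gives 108000 nM
compound 2 `O=[N+]([O-])C1=CNc2nc(C(F)(F)F)nn2C1c1c(O)cc(O)cc1O` gives 838000 nM
compound 3 `CSc1nc2n(n1)C(O)C([N+](=O)[O-])=NN2` gives 99000 nM

Of these three, compound 1 (108000 nM) and compound 3 (99000 nM) lie within the scatter of each other, while compound 2 (838000 nM) stands clearly above both. Compound 1 therefore sits in the lower pair of a very small set, and no two of the measured compounds differ in only one place.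

The next compound, compound 4 `O=[N+]([O-])C1=CNc2nc(-c3ccco3)nn2C1c1ccc(O)cc1O`, keeps the core of compound 1 and carries 2,4-dihydroxyphenyl in place of hydrogen on a saturated ring carbon. Among the compounds with values here, the only guide among the measured compounds is compound 2 (838000 nM), which also has a hydroxylated aromatic ring on a saturated ring carbon. It differs from compound 1 elsewhere as well, so this single comparison cannot isolate the effect of the new group, and the expectation stays cautious. In this assay a moderate upward step is expected (a 2.0-fold higher number from compound 1 to compound 4 (0.31 log units; beyond the scatter)), smaller than the gap that separates the values of compound 1 and compound 2. For compound 4 the expected value is 220000 nM (estimated range 70000 nM to 700000 nM).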

Compound 4, half-maximal cytotoxic concentration: 119000 nM
Compound 4: middle estimate off by 1.8-fold (0.27 log units), on the high side, and the stated range covers the measured number.
By their numbers in this assay, from the lowest: compounds 3, 1 and 4 (each within the scatter of the next); then compound 2.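

In this assay, within the data shown here, the step from hydrogen to 2,4-dihydroxyphenyl on the saturated ring carbon gives the first reading of a change in one place, and it lies within the scatter: a 1.1-fold higher number from compound 1 to compound 4 (0.04 log units; within the scatter). This position, next to the ring nitrogen and next to the ring atom that bears a nitro group, therefore accepts this large aromatic substituent on the core of compound 1 with no difference that can be read in this assay. Nothing measured here speaks to why the two numbers lie so close together.

On these data alone, it remains open whether other groups on this saturated ring carbon, such as an amine, a carboxylic acid or an unsubstituted phenyl, would also stay within the scatter of compound 1, and whether the two hydroxyl groups of the new ring play any part in the result. Compound 2, at 838000 nM, differs from compound 4 in more than one place, so the compounds shown cannot tie its number to any single group.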